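From acetamido to methyl: the expected shift for compound 4

The source may report more compounds than this note shows. Statements on the series, on what has been measured and on what is new or still open speak of the compounds shown alone.

compound 1 `CC(=O)Nc1ccc2[nH]c(C)nc2c1` gives 0.61
compound 2 `CCCCC(=O)Nc1ccc2[nH]c(C)nc2c1` gives 2.11
compound 3 `c1ccc2cc(Cc3nc4ccccc4[nH]3)ccc2c1` gives 4.79

All three values come from a physicochemical assay for lipophilicity (on this read-out lower numbers stand for lower lipophilicity and higher numbers for higher lipophilicity), and compound 1 at 0.61 is the lowest of the three numbers. Compound 2 is its nearest neighbour and compound 3 the furthest. The next structure is compound 4 `Cc1ccc2[nH]c(C)nc2c1` with methyl in place of acetamido on an aromatic carbon, in counted form methyl in place of acetamido on an aromatic carbon and with nothing else altered.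

Going by the values given here, only one measured step is available: a number 1.50 log units higher from compound 1 to compound 2 (beyond the scatter) is large, with propyl in place of hydrogen on a saturated chain carbon bound to a carbonyl carbon. Among the compounds with values here, that change sits on the chain and not on the aromatic carbon, so it gives a scale for the series and no direct precedent. Within the data shown here, no measured step removes acetamido. Compound 3 carries no acetamido and stands at 4.79 on the same scale, but it differs from compound 1 in more than one place, so its support is weak.

A rise in this assay beyond the scatter is therefore expected, similar in size to the propyl step. The estimated step is a number 1.49 log units higher from compound 1 to compound 4 (beyond the scatter) for this replacement. For compound 4 the estimated value is 2.1 with an expected range from 1.6 to 2.6 on this scale.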

Compound 4, partition coefficient: 1.94
For compound 4 the middle estimate is 0.16 log units above the measured one, within the range that was stated.
By their numbers in this assay, from the lowest: compound 1; then compounds 4 and 2 (each within the scatter of the next); then compound 3.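

In this assay, the aromatic carbon of the core now has its own measured replacement, where the step is a number 1.33 log units higher from compound 1 to compound 4 (beyond the scatter) and is large; the earlier step changed only the chain on the carbonyl carbon and left acetamido's amide in place. Here the hydrogen-bond donor and acceptor counted on acetamido do not return in methyl, and compound 2 at 2.11 and compound 4 at 1.94 lie within the scatter of each other, so extending the amide chain with propyl and replacing the whole acetamido with methyl end at readings that this assay does not separate. Nothing at hand ties the step to a measured property of either group.

From the compounds shown here alone, the series holds this single replacement on a single core, so whether the step carries over to other cores remains open. Also open, going by these compounds, is how an amine, a carboxylic acid or a longer chain such as ethyl on the same aromatic carbon would read in this assay relative to methyl and acetamido.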